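A few compounds are considered here, and "the series" means these few. Any claim that something is new, unique, unknown or untested is made for them only; others in the source may bear on it.

Measured to date:
compound 1 `CC(C)(C)OC(=O)NCCCNC(=O)CN1CN(c2ccccc2)C2(CCN(C(=O)c3ccc(C(C)(C)C)cc3)CC2)C1=O`: 4500 nM
compound 2 `CC(C)(C)OC(=O)NCC1CCCN(C(=O)CN2CN(c3ccccc3)C3(CCN(C(=O)c4ccc(C5CCCCC5)cc4)CC3)C2=O)C1`: 3800 nM
compound 3 `O=C(CN1CN(c2ccccc2)C2(CCN(C(=O)c3ccc(C4CCCCC4)cc3)CC2)C1=O)N1CCC(CO)CC1`: 1100 nM

All three were run in an assay on HEK293 cells for displacement of a labelled ligand from NPC1-like intracellular cholesterol transporter 1 (Homo sapiens); a lower number here means a stronger inhibitor, a higher number a weaker inhibitor. Compound 1 carries the highest number of the three; the value of compound 2 lies within the scatter of it, so no order between these two can be drawn, while the value of compound 3 lies beyond the scatter below that of compound 1.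

Compound 4 `CC(C)(C)c1ccc(C(=O)N2CCC3(CC2)C(=O)N(CC(=O)NCCCCO)CN3c2ccccc2)cc1` is the next entry, not yet measured. Compared with compound 1 the change is hydroxymethyl in place of (tert-butoxycarbonyl)amino on a saturated chain carbon, three bonds along the chain from an amide-type nitrogen. For the measured compounds named here, no measured pair shows this change on its own, so the step must be judged from the values of the three compounds above.

For compound 4 a step of a 1.5-fold lower number from compound 1 to compound 4 (0.18 log units; within the scatter) is expected, i.e. a small lowering that may well stay within the scatter. The estimate for compound 4 is 3000 nM, with a range of 1000 nM to 9000 nM.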

Compound 4, half-maximal inhibitory concentration: 19200 nM
For compound 4 the middle estimate is 6.4-fold (0.81 log units) below the measured one; measured number above the stated range.
By their numbers in this assay, from the lowest: compound 3; then compounds 2 and 1 (each within the scatter of the next); then compound 4.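

In this assay, hydroxymethyl in place of (tert-butoxycarbonyl)amino on a saturated chain carbon, three bonds along the chain from an amide-type nitrogen, gives a 4.3-fold higher number from compound 1 to compound 4 (0.63 log units; beyond the scatter) and so weakens inhibition beyond the scatter. For the compounds shown here, this is the first one-place comparison, and it shows that this position is sensitive to this change. No available data bear on the reason for the loss.

Still open, going by these compounds, is whether a free amine or a carboxylic acid at this position would fare better than hydroxymethyl. Also open, on these data alone, is whether a longer chain carrying the same hydroxyl would recover inhibition.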